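The source may report more compounds than this note shows. Statements on the series, on what has been measured and on what is new or still open speak of the compounds shown alone.

Working notes on the series. Three compounds carry numbers in a functional assay on A549 cells (Homo sapiens) for antiproliferative activity, read by sulforhodamine B assay, with a stated time of 72 h; a lower number here means a stronger inhibitor, a higher number a weaker inhibitor. Compound 1 `COc1ncc(-c2ccc3ncnc(Nc4ccc(OCCO)c(F)c4)c3c2)cc1NS(=O)(=O)c1ccc(F)cc1F` gives 6640 nM; compound 2 `COC(=O)Cn1cc(Nc2ncnc3ccc(-c4cnc(OC)c(NS(=O)(=O)c5ccc(F)cc5F)c4)cc23)cn1` gives 4280 nM; compound 3 `COc1ncc(-c2ccc3ncnc(Nc4ccc(OCCO)nc4)c3c2)cc1NS(C)(=O)=O` gives 5080 nM. Compound 2 holds the lowest of the three numbers, but its gaps to compound 3 and to compound 1 both lie within the scatter, so no order among them is secure. The next member, compound 4 `COc1cc(Nc2ncnc3ccc(-c4cnc(OC)c(NS(=O)(=O)c5ccc(F)cc5F)c4)cc23)ccc1OCCO`, differs from compound 2 in one place: 4-(2-hydroxyethoxy)-3-methoxyphenyl in place of 1-((methoxycarbonyl)methyl)-1H-pyrazol-4-yl on a nitrogen on an aromatic ring. Among the compounds with values here, the only measured step bearing on this exchange runs the other way, a 1.6-fold lower number from compound 1 to compound 2 (0.19 log units; within the scatter), and stayed within the scatter. The reverse move from a pyrazole to a substituted phenyl is therefore expected to give a 1.3-fold higher number from compound 2 to compound 4 (0.11 log units; within the scatter). Compound 4 is estimated at 5500 nM, with a range from 2500 nM to 12000 nM.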

Compound 4, half-maximal inhibitory concentration: 3760 nM
For compound 4 the middle estimate is 1.5-fold (0.17 log units) above the measured one; measured number inside the range.
By their numbers in this assay, from the lowest: compounds 4, 2, 3 and 1 (each within the scatter of the next).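

Exchanging 1-((methoxycarbonyl)methyl)-1H-pyrazol-4-yl for 4-(2-hydroxyethoxy)-3-methoxyphenyl on the nitrogen stays within the scatter in this assay (a 1.1-fold lower number from compound 2 to compound 4 (0.06 log units; within the scatter)), so this place holds either a five-membered or a six-membered aromatic ring with no readable difference. Methoxy in place of fluoro on an aromatic carbon, a change no earlier pair showed, also stays within the scatter (a 1.8-fold lower number from compound 1 to compound 4 (0.25 log units; within the scatter)). No evidence on hand explains either step. No group at this place yet separates from the others beyond the scatter. As far as these compounds go, whether an amine or a carboxylic acid in place of the 2-hydroxyethoxy chain would do so remains open.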